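Furan for Thiophene on a Fused Lactone Core

The compounds below may be only part of what the source reports. "The series", "measured", "known", "first", "only" and "open" are said of these compounds alone.

Compound 2 `CC1(C)CC(=O)C2=C(C1)OC(=O)C(NC(=O)c1ccccc1)C2c1cccs1` was tested in a functional assay on SW 1116 cells (Homo sapiens) for cytotoxicity, read by MTT assay, with a stated time of 24 h, tested at 10 ug/mL (a lower number here means a stronger effect, a higher number a weaker effect of the compound at the concentration tested), where compound 2 gives 50.5%. Among the three measured compounds it stands second highest. Among the measured compounds shown here, its nearest neighbour is compound 1 `CC1(C)CC(=O)C2=C(C1)OC(=O)C(NC(=O)c1ccccc1)C2c1ccc([N+](=O)[O-])cc1`, which gives 46.6%; the only measured step leading into compound 2, a number 3.9 percentage points higher from compound 1 to compound 2 (within the scatter), lies within the scatter. For the measured compounds named here, compound 3 `O=C1CCCC2=C1C(c1cccs1)C(NC(=O)c1ccccc1)C(=O)O2` gives 69.7%, the number furthest from that of compound 2 and beyond the scatter, but compound 3 differs from compound 2 in the core rather than at the saturated ring carbon, so no measured step from it bears on the present change.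

Compound 4 `CC1(C)CC(=O)C2=C(C1)OC(=O)C(NC(=O)c1ccccc1)C2c1ccco1` carries furan-2-yl in place of thiophen-2-yl on a saturated ring carbon. Going by the values given here, the one step that bears on this position, a number 3.9 percentage points higher from compound 1 to compound 2 (within the scatter), was within the scatter even though it exchanged two rather different groups; the move from thiophen-2-yl to furan-2-yl keeps the same ring size and heteroatom count. The step of a number 0.5 percentage points higher from compound 2 to compound 4 (within the scatter) is therefore expected to stay within the scatter. Compound 4 is estimated at 51%, with a range from 38% to 64%.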

Compound 4, a percentage reported as activity, at one concentration (the size of the read-out at that concentration, not a potency): 42%
The estimate for compound 4 lay 9 percentage points above the measured number, and the stated range covers the measured number.
By their numbers in this assay, from the lowest: compounds 4, 1 and 2 (each within the scatter of the next); then compound 3.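

In this assay, furan-2-yl in place of thiophen-2-yl on the saturated ring carbon gave a number 8.5 percentage points lower from compound 2 to compound 4 (within the scatter), and furan-2-yl in place of 4-nitrophenyl at the same carbon gave a number 4.6 percentage points lower from compound 1 to compound 4 (within the scatter). On this shared core, the three groups at this position therefore cannot be told apart in this assay, and exchanging the sulfur of the five-membered aromatic ring for oxygen adds a second heteroatom exchange that stays within the scatter. No supporting measurement is available to account for this result.

Going by these compounds, how an amine, a carboxylic acid or a longer alkyl chain on this carbon would read remains open. Also open, on these data alone, is whether furan-2-yl on the core of compound 3 would read as it does on the core of compound 2.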